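A few compounds are considered here, and "the series" means these few. Any claim that something is new, unique, unknown or untested is made for them only; others in the source may bear on it.

Series notes. Compound 1 `Nc1ccccc1NC(=O)c1ccc(NC(=S)NCc2cncc(Br)c2)cc1` and compound 2 `Nc1ccc(CNC(=O)Nc2ccc(C(=O)Nc3ccccc3N)cc2)cn1` share the core of compound 1 and have both been measured in an assay on isolated protein for inhibition of Nicotinamide phosphoribosyltransferase (Homo sapiens), read by fluorescence, with stated times of 5 min and 15 min; a lower number here means a stronger inhibitor, a higher number a weaker inhibitor. Compound 1 gives only a limit in this assay, > 2000 nM, and no number. Compound 2 likewise reaches only the limit, > 2000 nM. Compound 1 therefore stands at the limit rather than at a value, and both shown values sit there (the limit of > 2000 nM in this assay, at which 2 of the 2 values shown sit), so no measured step within the shared core exists to lean on.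

Compound 3 `Nc1ccccc1NC(=O)c1ccc(NC(=S)NCc2ccccc2F)cc1` is not yet measured in this assay. Its difference from compound 1 is 2-fluorophenyl in place of 5-bromopyridin-3-yl on a saturated chain carbon bound to an amide-type nitrogen. Among the compounds with values here, with only limits at hand, no direction for the step to compound 3 can be read from the data. The working expectation is that compound 3 stays close to where compound 1 sits, so the estimated step is a step that the limit leaves unreadable from compound 1 to compound 3, within the scatter or not resolvable at all. Compound 3 is thus estimated at 3000 nM, with a range from 1200 nM to 8000 nM, and most likely reported as a limit again.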

Compound 3, half-maximal inhibitory concentration: > 2000 nM
Compound 3 ended at the assay's limit; the forecaster's own chance of this, stated with the estimate: 70%; the middle value does not contradict the limit.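

No new step can be read between compound 1 and compound 3 in this assay, since both stand at a limit and neither has a number: the limit of > 2000 nM in this assay, at which 3 of the 3 values shown sit.

The compounds shown leave open which change to the shared core would give a measurable value.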